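Series notes: replacing the 4-chlorophenyl group in compound 3

The source may report more compounds than this note shows. Statements on the series, on what has been measured and on what is new or still open speak of the compounds shown alone.

Three acylguanidines sharing one core have been measured in a functional assay for inhibition of sodium/hydrogen exchanger (Oryctolagus cuniculus); on this read-out higher numbers stand for weaker inhibition and lower numbers for stronger inhibition. Compound 1 `Cc1cc(F)c(S(C)(=O)=O)cc1C(=O)N=C(N)N` gives 44 nM. Compound 2 `Cc1cc(C)c(S(C)(=O)=O)cc1C(=O)N=C(N)N` gives 11 nM. Compound 3 `Cc1cc(-c2ccc(Cl)cc2)c(S(C)(=O)=O)cc1C(=O)N=C(N)N` gives 45 nM, the highest of the three numbers; its nearest neighbour is compound 1, with a 1.0-fold higher number from compound 1 to compound 3 (0.01 log units; within the scatter), while the larger gap is a 4.1-fold higher number from compound 2 to compound 3 (0.61 log units; beyond the scatter).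

Compound 4 `Cc1cc(SC(C)(C)C)c(S(C)(=O)=O)cc1C(=O)N=C(N)N` is not yet measured. It differs from compound 3 in one place: (tert-butyl)sulfanyl in place of 4-chlorophenyl on an aromatic carbon. For the measured compounds named here, the steps that bear on this site are a 4.0-fold lower number from compound 1 to compound 2 (0.60 log units; beyond the scatter) and a 4.1-fold higher number from compound 2 to compound 3 (0.61 log units; beyond the scatter), with the fluoro-to-4-chlorophenyl comparison essentially flat. At this position a methyl group carries the lowest number, while fluoro and 4-chlorophenyl sit together at the higher end. Going by the values given here, the (tert-butyl)sulfanyl group has no ring and fewer heavy atoms than 4-chlorophenyl, yet is larger than methyl, so no measured step matches it directly.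

On balance, compound 4 is expected to give 25 nM in this assay, with a range of 8 nM to 80 nM. The expected step is a 1.8-fold lower number from compound 3 to compound 4 (0.26 log units; within the scatter), a modest improvement that may fall within the scatter.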

Compound 4, half-maximal inhibitory concentration: 22 nM
Estimate against measurement, compound 4: 1.1-fold (0.06 log units) above; the range from low to high includes it.
By their numbers in this assay, from the lowest: compounds 2, 4, 1 and 3 (each within the scatter of the next, the first and the last beyond it).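

In this assay, the (tert-butyl)sulfanyl group of compound 4 gives the first measured separation from 4-chlorophenyl at this position, ortho to the methylsulfonyl group (a 2.0-fold lower number from compound 3 to compound 4 (0.31 log units; beyond the scatter)), a modest step that removes the ring. The new group cannot be told apart from either methyl (a 2.0-fold higher number from compound 2 to compound 4 (0.30 log units; within the scatter)) or fluoro (a 2.0-fold lower number from compound 1 to compound 4 (0.30 log units; within the scatter)), although those two are separated from each other (a 4.0-fold lower number from compound 1 to compound 2 (0.60 log units; beyond the scatter)), so compound 4 fills the gap without settling beside either one. The measurements in hand give no explanation for these steps.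

The compounds shown leave open whether the step belongs to the sulfur atom or to the tert-butyl part, and a tert-butyl group joined directly to the ring, a tert-butoxy group or a methylsulfanyl group would help to separate the two. Also open, on these data alone, is how an amine or a carboxylic acid at this position would read in this assay, and whether any group can clearly improve on compound 2 at 11 nM.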